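The source may hold more compounds than are shown below. What is called first, only, known or untested is meant among the compounds shown, and "the series" means these compounds.

The three measured compounds share one core, and compound 1 `Cc1c(OCCCCOc2ccccc2C(=O)O)ccc(C(=O)CC(C)C)c1O` stands at the highest of the three numbers recorded in an assay on HEK293 cells for positive allosteric modulation of metabotropic glutamate receptor 2 (Rattus norvegicus), read by thallium flux, with a stated time of 2.5 min; on this read-out higher numbers stand for an effect only at larger amounts of compound and lower numbers for an effect already at smaller amounts. In this assay compound 1 gives 415 nM. Its nearest neighbour, compound 2 `Cc1c(OCCCCOc2ccccc2C(=O)O)ccc(C(=O)CC2CCCC2)c1O`, gives 335 nM, and the change a 1.2-fold lower number from compound 1 to compound 2 (0.09 log units; within the scatter) lies within the scatter. Compound 3 `CC(=O)c1ccc(OCCCCOc2ccc(F)c(C(=O)O)c2)c(C)c1O`, which gives 259 nM in this assay, differs from compound 1 in more than one place, so its value and that of compound 1 are merely placed side by side; they are within the scatter of each other.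

The untested compound 4 `Cc1c(OCCCCOc2ccc(C(=O)O)cc2Cl)ccc(C(=O)CC(C)C)c1O` carries a change at a different place: 4-carboxy-2-chlorophenyl in place of 2-carboxyphenyl on an oxygen on a saturated carbon. Among the measured compounds shown here, none of the measured steps touches the ether-linked aryl carboxylic acid, so no step bears on this change directly. For the measured compounds named here, the only measured step, on the saturated chain carbon bound to the carbonyl carbon, was within the scatter, and the three measured numbers all sit within the scatter of one another. With nothing shown to move the number, the estimate for compound 4 is a step of a 1.1-fold higher number from compound 1 to compound 4 (0.04 log units; within the scatter) that stays within the scatter. Compound 4 is therefore expected to give about 450 nM in this assay, with a range from 150 nM to 1400 nM.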

Compound 4, half-maximal effective concentration: 96 nM
Beside the measured number, compound 4's estimate is 4.7-fold (0.67 log units) above it; measured number outside the range, below it.
By their numbers in this assay, from the lowest: compound 4; then compounds 3, 2 and 1 (each within the scatter of the next).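

In this assay, replacing 2-carboxyphenyl with 4-carboxy-2-chlorophenyl on the oxygen on a saturated carbon gives a 4.3-fold lower number from compound 1 to compound 4 (0.64 log units; beyond the scatter) and is the only step shown that lies beyond the scatter. This shows that the number responds to the ether-linked aryl carboxylic acid, a part of the molecule that the earlier step on the saturated chain carbon did not touch, and that this change leads to an effect at smaller amounts of compound. No measurement available here accounts for the step, so its cause remains unexplained.

The change alters the numbered place of the carboxy group and adds a chlorine in a single step, so the compounds shown cannot assign the step to either alteration; a 4-carboxyphenyl group without the chlorine would separate the two. Going by these compounds, it also remains open whether a bromine or a methyl group could stand in for the chlorine, and whether the same exchange would produce a similar step on the cyclopentyl side chain of compound 2.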